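Liver microsome stability across the amide-substituent swap

This account rests on a few compounds, and the source may have more. Where it says the series, first, only, none or still open, it means among the compounds named here.

Compound 2 `CC[C@]1(C(=O)O)CC[C@H](C(=O)N2CC[C@](c3ccc(C(F)(C(F)(F)F)C(F)(F)F)cc3)(S(=O)(=O)c3ccc(F)cc3)C2)CC1` gives 100% in an ADME assay on microsomes from liver (Homo sapiens) for metabolic stability, with a stated time of 10 min (a lower number here means that less of the compound is left, a higher number that more of the compound is left), the higher of the two numbers recorded, with compound 1 `C[C@]1(C(=O)O)CC[C@H](C(=O)N2CC[C@](c3ccc(C(F)(C(F)(F)F)C(F)(F)F)cc3)(S(=O)(=O)c3ccc(F)cc3)C2)CC1` at 97%; the step of a number 3 percentage points higher from compound 1 to compound 2 (within the scatter) stays within the scatter. Compound 3 `O=C(C1CCS(=O)(=O)CC1)N1CC[C@](c2ccc(C(F)(C(F)(F)F)C(F)(F)F)cc2)(S(=O)(=O)c2ccc(F)cc2)C1` carries a different change: 1,1-dioxothian-4-yl in place of 4-carboxy-4-ethylcyclohexyl on a carbonyl carbon. Among the compounds with values here, no measured step touches the ring on the carbonyl carbon, and the one known step was small. With compound 2 already near full recovery, the step of a number 15 percentage points lower from compound 2 to compound 3 (beyond the scatter) is expected to be flat to slightly downward. For compound 3 the estimate is 85%, ranging from 60% to 100%.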

Compound 3, percent of the compound remaining: 93%
Compound 3: middle estimate off by 8 percentage points, on the low side; the range from low to high includes it.
By their numbers in this assay, from the lowest: compounds 3, 1 and 2 (each within the scatter of the next).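

In this assay, 1,1-dioxothian-4-yl in place of 4-carboxy-4-ethylcyclohexyl on the carbonyl carbon gives a number 7 percentage points lower from compound 2 to compound 3 (within the scatter), and in place of 4-carboxy-4-methylcyclohexyl it gives a number 4 percentage points lower from compound 1 to compound 3 (within the scatter). This place on the carbonyl carbon therefore accepts a full exchange of the ring, with the carboxylic acid gone and sulfur in the ring, and neither step leaves the scatter. No supporting data bear on these readings.

From the compounds shown here alone, whether an amine on the ring, or an open chain in place of the ring, would stay within this range remains open. All three readings sit near the top of the scale, which leaves little room for separating further changes at this place.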